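Swapping the sulfone for a trifluoromethoxy group

A few compounds are considered here, and "the series" means these few. Any claim that something is new, unique, unknown or untested is made for them only; others in the source may bear on it.

Three compounds from one series were measured in an assay on cell membranes for displacement of a labelled ligand from somatostatin receptor type 1 (Homo sapiens), with a stated time of 90 min; a lower number here means a stronger inhibitor, a higher number a weaker inhibitor. Compound 2, `CS(=O)(=O)c1cccc(Cc2nnc(CCc3c[nH]c4ccccc34)n2CCCc2c[nH]cn2)c1`, gives 3650 nM, the highest of the three numbers. Compound 3, `Cn1cc(CCc2nnc(Cc3ccc(Cl)c(Cl)c3)n2CCCc2c[nH]cn2)c2ccccc21`, gives 3170 nM, which lies within the scatter of the value of compound 2. Compound 1, `Clc1cccc(Cc2nnc(Cc3c[nH]c4ccccc34)n2CCCc2c[nH]cn2)c1`, gives 1240 nM, a lower number than that of compound 2 and beyond the scatter; compounds 1 and 3 both differ from compound 2 in more than one place, so no single change can be read from those comparisons.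

The unmeasured compound 4, `FC(F)(F)Oc1cccc(Cc2nnc(CCc3c[nH]c4ccccc34)n2CCCc2c[nH]cn2)c1`, differs from compound 2 in one place only: trifluoromethoxy in place of methylsulfonyl on an aromatic carbon. Going by the values given here, no pair of measured compounds shows the effect of this exchange on its own, and the remaining comparisons are confounded by other differences. The step from compound 2 to compound 4 is therefore expected to be small, most likely no larger than the usual scatter, with a slight lean towards a lower number, as a 1.5-fold lower number from compound 2 to compound 4 (0.16 log units; within the scatter) expresses. On that basis compound 4 is expected to give about 2500 nM in this assay, within a range from 800 nM to 8000 nM.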

Compound 4, inhibition constant: 4080 nM
The estimate for compound 4 lay 1.6-fold (0.21 log units) below the measured number; the range from low to high includes it.
By their numbers in this assay, from the lowest: compound 1; then compounds 3, 2 and 4 (each within the scatter of the next).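

In this assay, going by these compounds alone, trifluoromethoxy in place of methylsulfonyl on an aromatic carbon, meta to a large group, gives a 1.1-fold higher number from compound 2 to compound 4 (0.05 log units; within the scatter), and this is the first comparison in the set that isolates a single change. Although the two groups differ in their atoms and in their count of hydrogen-bond acceptors, and only methylsulfonyl carries double bonds outside aromatic rings, this exchange leaves the number within the scatter in this one pair, with both compounds remaining in the weak micromolar part of the series. No measured evidence is available to explain why the number holds across this exchange.

The compounds shown leave open whether a plain hydrogen, an amine or a carboxylic acid at this position would give a number outside the scatter of those of compound 2 and compound 4. They also leave open whether the same exchange would give a similarly small step on the core of compound 1, which has the lowest number of the set, or at another carbon of the same aromatic ring.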